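Hydroxy for methyl on a side chain of a feeble core

The compounds below may be only part of what the source reports. "The series", "measured", "known", "first", "only" and "open" are said of these compounds alone.

Compound 1 `CCCn1c(N)c(-c2nc3ccccc3[nH]2)c2nc(C#N)c(C#N)nc21` serves as the reference. In a functional assay on HL-60 cells (Homo sapiens) for antiproliferative activity, read by MTT assay, with a stated time of 48 h (a lower number here means a stronger inhibitor, a higher number a weaker inhibitor), compound 1 gives 45200 nM. Compound 2 `N#Cc1nc2c(-c3nc4ccccc4[nH]3)c(N)n(CCO)c2nc1C#N` carries a hydroxy in place of methyl on a saturated chain carbon, two bonds along the chain from an aromatic nitrogen, the difference being (hydroxy in place of methyl on a saturated chain carbon, two bonds along the chain from an aromatic nitrogen). In this assay compound 2 reaches only the limit of the assay, > 50000 nM, and no number. Compound 3 `CCCCn1c(N)c(-c2nc3ccccc3[nH]2)c2nc(C#N)c(C#N)nc21` differs from compound 1 by methyl in place of hydrogen on a saturated chain carbon, three bonds along the chain from an aromatic nitrogen. In this assay compound 3 likewise sits at the limit, > 50000 nM, which is not a number. The change from compound 1 to compound 2 makes an at least 1.1-fold higher number from compound 1 to compound 2 (0.04 log units; that floor lies within the scatter), and the change from compound 1 to compound 3 makes an at least 1.1-fold higher number from compound 1 to compound 3 (0.04 log units; that floor lies within the scatter), while between compound 2 and compound 3 there is a step that the two limits leave unreadable from compound 2 to compound 3; all three readings are shaped by the limit of > 50000 nM in this assay, at which 2 of the 3 values shown sit.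

Compound 4 `N#Cc1nc2c(-c3nc4ccccc4[nH]3)c(N)n(CCCO)c2nc1C#N` is not yet measured. It differs from compound 3 by hydroxy in place of methyl on a saturated chain carbon, three bonds along the chain from an aromatic nitrogen. Within the data shown here, this is the same kind of change as the one from compound 1 to compound 2, but the place is not the same: in compound 2 the hydroxy sits two bonds along the chain from an aromatic nitrogen, in compound 4 three bonds along the chain. The earlier hydroxy for methyl step moved compound 2 from a number to the limit, and compound 3 already sits at the limit, so compound 4 is expected to show a step that the limit leaves unreadable from compound 3 to compound 4, an expectation resting on compound 3 giving > 50000 nM. Compound 4 is estimated at 65000 nM, expected to lie between 30000 nM and 160000 nM.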

Compound 4, half-maximal inhibitory concentration: > 50000 nM
Compound 4: a limit, no number; the forecaster's own chance of this, stated with the estimate: 80%; the middle value does not contradict the limit.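

In this assay compound 4 gives > 50000 nM, which is a limit of the assay and not a number. Among these compounds, the hydroxy for methyl change therefore cannot be followed from one chain to the other, and the steps from compound 3 to compound 4 and from compound 2 to compound 4 cannot be read, because both ends of each sit at a limit: the limit of > 50000 nM in this assay, at which 3 of the 4 values shown sit. The one step that can be read is an at least 1.1-fold higher number from compound 1 to compound 4 (0.04 log units; that floor lies within the scatter), so the result shows only that compound 4 joins compound 2 and compound 3 at the same limit, and it does not show whether the change acts alike or differently on the two chains, nor how large it is in either place.

Among the compounds shown, only compound 1 gives a number, 45200 nM, so the series offers no second measured value against which any side-chain change could be sized. On these data alone, whether an amine or a carboxylic acid at the end of the chain, or a longer chain, would bring the shared core to a readable number in this assay stays open.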